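Three Aryl Amides Measured, a Fourth Awaiting Its Number

A few compounds are considered here, and "the series" means these few. Any claim that something is new, unique, unknown or untested is made for them only; others in the source may bear on it.

Compound 1 `CN(C)C(=O)c1cc2cnc(Nc3ccc(NC(=O)C4(C(=O)Nc5ccccc5F)CC4)cc3)nc2n1C1CCCC1` carries a 2-fluorophenyl on an amide-type nitrogen. In a functional assay on SiHa cells (Homo sapiens) for inhibition, read by CCK-8 assay, with a stated time of 72 h, tested at 10 uM (on this read-out higher numbers stand for more inhibition of growth at the one concentration tested and lower numbers for less inhibition of growth), compound 1 gives 103%, the highest of the three numbers at hand, though its companions sit close: compound 2 `CN(C)C(=O)c1cc2cnc(Nc3ccc(NC(=O)C4(C(=O)Nc5ccc(Br)cc5)CC4)cc3)nc2n1C1CCCC1` gives 98.8%, and compound 3 `CN(C)C(=O)c1cc2cnc(Nc3ccc(NC(=O)C4(C(=O)Nc5cccc(Cl)c5)CC4)cc3)nc2n1C1CCCC1` gives 97.3%. The step of a number 4.2 percentage points lower from compound 1 to compound 2 (within the scatter) and the step of a number 5.7 percentage points lower from compound 1 to compound 3 (within the scatter) are both within the scatter, as is a number 1.5 percentage points lower from compound 2 to compound 3 (within the scatter). No order among the three can be read from these readings; all three lie near complete inhibition of growth at the single concentration tested.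

Compound 4 `Cc1ccc(NC(=O)C2(C(=O)Nc3ccc(Nc4ncc5cc(C(=O)N(C)C)n(C6CCCC6)c5n4)cc3)CC2)cc1` differs from compound 1 on that same amide-type nitrogen: 4-methylphenyl in place of 2-fluorophenyl on an amide-type nitrogen. The two measured steps from compound 1 bear directly on this change, since each likewise exchanged the aryl group on that amide-type nitrogen, and each moved the reading only within the scatter. The exchange for 4-methylphenyl is expected to behave alike, with no step beyond the scatter in either direction. Compound 4 is accordingly expected at 99%, between 89% and 106%. The step this estimate means, a number 4 percentage points lower from compound 1 to compound 4 (within the scatter), is expected to remain inside the usual scatter.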

Compound 4, percent growth inhibition at one concentration: 104%
Compound 4: middle estimate off by 5 percentage points, on the low side; low and high end bracket the measured number.
By their numbers in this assay, from the lowest: compounds 3, 2, 1 and 4 (each within the scatter of the next).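

In this assay, compound 4 extends the set of groups tolerated on this amide-type nitrogen to one with no halogen, as 4-methylphenyl is made of carbon only, and none of its steps leaves the scatter: a number 1 percentage points higher from compound 1 to compound 4 (within the scatter), a number 6.7 percentage points higher from compound 3 to compound 4 (within the scatter) and a number 5.2 percentage points higher from compound 2 to compound 4 (within the scatter). The last of these steps is the direct exchange of bromo for methyl on the aromatic carbon, and it shows that, among these four compounds, a halogen on the phenyl ring is not required for a reading near complete inhibition of growth at this single concentration. Nothing presented here accounts for the four aryl groups reading alike.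

What the compounds shown leave open is whether this tolerance extends to an amine or a carboxylic acid on the phenyl ring, or to a longer chain or a saturated cyclohexyl ring in place of the phenyl ring. With all four readings so close together at one concentration, they also leave open whether these aryl groups would separate at lower concentrations.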